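The source may hold more compounds than are shown below. What is called first, only, known or untested is meant among the compounds shown, and "the series" means these compounds.

Measured compounds in a functional assay on OVCAR-5 cells (Homo sapiens) for cytotoxicity, read by sulforhodamine B assay, with a stated time of 48 h; a lower number here means that less compound is tolerated, a higher number that more compound is tolerated: compound 1 `ClCc1ccccc1Cn1cnc2c(Cl)nc(Cl)nc21` gives 5620 nM; compound 2 `ClCc1cccc(Cn2cnc3c(Cl)ncnc32)c1` gives 8910 nM; compound 3 `ClCc1ccc(Cn2cnc3c(Cl)nc(Cl)nc32)cc1` gives 66100 nM.

Compound 2 stands second highest of the three numbers. Its nearest neighbour is compound 1, whose number is lower but within the scatter; compound 3 is furthest, with a number beyond the scatter higher. For the measured compounds named here, no step between measured compounds that differ in one place is available here.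

Compound 4 `Nc1nc(Cl)c2ncn(Cc3cccc(CCl)c3)c2n1` differs from compound 2 by amino in place of hydrogen on an aromatic carbon. Going by the values given here, nothing among the measured compounds tells how this change acts, so the step from compound 2 to compound 4 is estimated as modest and its direction uncertain, as a 1.3-fold higher number from compound 2 to compound 4 (0.13 log units; within the scatter). Compound 4 is expected to give about 12000 nM in this assay, between 3500 nM and 40000 nM.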

Compound 4, concentration lethal to 50% of the cells: 57500 nM
Compound 4: middle estimate off by 4.8-fold (0.68 log units), on the low side, outside the stated range (above it).
By their numbers in this assay, from the lowest: compounds 1 and 2 (each within the scatter of the next); then compounds 4 and 3 (each within the scatter of the next).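

In this assay amino in place of hydrogen on an aromatic carbon, between two ring nitrogen atoms, is not a silent change: more of compound 4 is tolerated (a 6.5-fold higher number from compound 2 to compound 4 (0.81 log units; beyond the scatter)). For the compounds shown here, as the only step here that isolates one place, it shows that this position of the shared core bears on cytotoxicity in these cells. Nothing measured accounts for the size of this step.

Whether the rise is specific to amino stays open, as the compounds shown include no methylamino, hydroxyl or methoxy group at this position. Also open, as far as these compounds go, is whether amino acts alike with the chloromethyl group placed elsewhere.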